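This account rests on a few compounds, and the source may have more. Where it says the series, first, only, none or still open, it means among the compounds named here.

Compound 3 `CC(Oc1ccccc1-c1cccnc1)C1=NCCN1` has been tested in a functional assay on CHO cells for agonist activity at Alpha-2B adrenergic receptor (Homo sapiens) (on this read-out lower numbers stand for smaller maximal responses and higher numbers for larger maximal responses), where compound 3 gives 0.5. Compound 1 `CC(Nc1ccccc1-c1ccccc1)C1=NCCN1` gives 0.5 in this assay, so compound 3 stands level with compound 1 at the digits shown, within the usual scatter. Compound 2 `CC(Oc1ccccc1-c1ccc([N+](=O)[O-])cc1)C1=NCCN1` gives only a limit of this assay, < 0.3. One of the three values shown thus sits at a limit (the limit of < 0.3 in this assay, at which 1 of the 3 values shown sits). The unmeasured compound 4 `CC(Oc1ccccc1-c1cccs1)C1=NCCN1` differs from compound 3 in one place: thiophen-2-yl in place of pyridin-3-yl on an aromatic carbon. Among the measured compounds shown here, no step between measured compounds covers such a change, and a step no larger than the scatter, in either direction, is expected. Compound 4 is accordingly expected to give 0.5, with a range from 0.3 to 0.7. The step this estimate implies is no change at the digits printed from compound 3 to compound 4 (within the scatter).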

Compound 4, intrinsic activity: the largest response reached, as a fraction of the reference agonist's: 0.6
Compound 4: the middle estimate sits 0.10 below what was measured, within the range that was stated.
By their numbers in this assay, from the lowest: compounds 1, 3 and 4 (each within the scatter of the next). At a limit, below all of these: compound 2.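

In this assay, thiophen-2-yl in place of pyridin-3-yl on an aromatic carbon gives a number 0.10 higher from compound 3 to compound 4 (within the scatter). Among the compounds shown here, at this place, ortho to a group of 8 heavy atoms, a five-membered aromatic ring with sulfur and a six-membered aromatic ring with nitrogen therefore cannot be told apart on this read-out, a comparison that no earlier pair offered. Nothing given here accounts for the size of this step.

On these data alone, what remains open is whether the response would hold with a group other than an aromatic ring at this place, such as a simple amine or a carboxylic acid. The compounds shown also leave open how thiophen-3-yl or pyridin-2-yl would compare.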